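Aryl variation on the shared core: compound 3 to compound 4

This account rests on a few compounds, and the source may have more. Where it says the series, first, only, none or still open, it means among the compounds named here.

Values in a functional assay on HCT-116 cells (Homo sapiens) for antiproliferative activity, read by MTT assay, with a stated time of 72 h; on this read-out lower numbers stand for stronger inhibition and higher numbers for weaker inhibition:
compound 1 `COc1ccc(-c2cn(C/C=C3\OC(=O)C(OCc4ccccc4)=C3OCc3ccccc3)nn2)cc1` gives > 100000 nM, a limit of the assay.
compound 2 `O=C1O/C(=C\Cn2cc(-c3cccc(O)c3)nn2)C(OCc2ccccc2)=C1OCc1ccccc1` gives 63600 nM.
compound 3 `CCCCCc1ccc(-c2cn(C/C=C3\OC(=O)C(OCc4ccccc4)=C3OCc3ccccc3)nn2)cc1` gives > 100000 nM, also a limit of the assay.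

Compound 3 thus stands only as a limit in this assay, with no number of its own; (the limit of > 100000 nM in this assay, at which 2 of the 3 values shown sit). Toward compound 1 the data give a step that the two limits leave unreadable from compound 1 to compound 3, and toward compound 2 they give an at least 1.5-fold higher number from compound 2 to compound 3 (0.19 log units; that floor lies within the scatter). Compound 4 `COc1ccccc1-c1cn(C/C=C2\OC(=O)C(OCc3ccccc3)=C2OCc2ccccc2)nn1` differs from compound 3 by 2-methoxyphenyl in place of 4-pentylphenyl on an aromatic carbon. Among the compounds with values here, the only measured step touching a methoxy-for-pentyl exchange is the one from compound 1 to compound 3, and that step is unreadable between two limits; compound 1, which carries 4-methoxyphenyl, sits at the limit itself. No step beyond the scatter is therefore expected in this assay, and a further limit is the most likely outcome. Compound 4 is expected at 100000 nM, within 40000 nM to 300000 nM. The estimated step is a number no higher from compound 3 to compound 4 (the limit leaves the size open).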

Compound 4, half-maximal inhibitory concentration: > 100000 nM
Compound 4 ended at the assay's limit; the forecaster's own chance of this, stated with the estimate: 70%; the middle value lies on the limit itself.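

In this assay, 2-methoxyphenyl on the aromatic carbon of the shared core joins 4-methoxyphenyl and 4-pentylphenyl at the limit, so moving the methoxy group to this other ring position gives no measurable value: the limit of > 100000 nM in this assay, at which 3 of the 4 values shown sit.

Within the data shown here, compound 2, with its 3-hydroxyphenyl, remains the only compound with a number, and the comparison gives an at least 1.5-fold higher number from compound 2 to compound 4 (0.19 log units; that floor lies within the scatter). The steps that link compound 4 to compound 1 and to compound 3 cannot be read, as both ends of each are limits.

As far as these compounds go, how far compound 1, compound 3 and compound 4 lie past the limit stays open, as does whether the value of compound 2 depends on the hydroxy group itself. From the compounds shown here alone, whether an amine or a carboxylic acid on this phenyl ring would give a value clearly beyond the scatter from compound 2 is also open.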